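Halogen swap on the aryl ketone of the pyrazole chalcone series

The source may report more compounds than this note shows. Statements on the series, on what has been measured and on what is new or still open speak of the compounds shown alone.

For the measured compounds named here, compound 2 `COc1cc(-c2cc(/C=C/C(=O)c3ccc(Cl)c(Cl)c3)[nH]n2)cc(OC)c1OC` gives 63300 nM in a functional assay on SF-268 cells (Homo sapiens) for inhibition, read by sulforhodamine B assay, with a stated time of 48 h (on this read-out higher numbers stand for weaker inhibition of growth and lower numbers for stronger inhibition of growth), the highest of the two numbers measured; the only neighbour is compound 1 `COc1cc(-c2cc(/C=C/C(=O)c3ccc(N)cc3)[nH]n2)cc(OC)c1OC`, which gives 3930 nM. Compound 3 `COc1cc(-c2cc(/C=C/C(=O)c3ccc(F)c(F)c3)[nH]n2)cc(OC)c1OC` is not yet measured. The change is 3,4-difluorophenyl in place of 3,4-dichlorophenyl on a carbonyl carbon. Going by the values given here, no measured step exchanges one halogenated phenyl for another; the single known step, a 16-fold higher number from compound 1 to compound 2 (1.21 log units; beyond the scatter), concerns a different group and bears only indirectly. A step no larger than the scatter is therefore expected, with the number for compound 3 estimated at 45000 nM (range 12000 nM to 150000 nM), the expected step being a 1.4-fold lower number from compound 2 to compound 3 (0.15 log units; within the scatter).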

Compound 3, concentration for total growth inhibition: > 100000 nM
Compound 3: no number, only a limit; the forecaster's own chance of this, stated with the estimate: 10%; middle value at least 2.2-fold (0.34 log units) away from the limit.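

Compound 3 gives a limit rather than a number in this assay: the limit of > 100000 nM in this assay, at which 1 of the 3 values shown sits.

On these data alone, the exchange of 3,4-dichlorophenyl for 3,4-difluorophenyl gives an at least 1.5-fold higher number from compound 2 to compound 3 (0.19 log units; that floor lies within the scatter), so this floor does not separate the two halogenated groups and the true size of the step stays unknown. The wider comparison gives an at least 25-fold higher number from compound 1 to compound 3 (1.40 log units; beyond the scatter), and with a 16-fold higher number from compound 1 to compound 2 (1.21 log units; beyond the scatter) it leaves the 4-aminophenyl group with the lowest number of the three on this carbonyl carbon.

As far as these compounds go, it remains open how far compound 3 lies past its limit. From the compounds shown here alone, it also remains open whether the amine itself accounts for the lower number of compound 1, a question that a 4-hydroxyphenyl or 4-acetamidophenyl group at this place would address.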